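This account rests on a few compounds, and the source may have more. Where it says the series, first, only, none or still open, it means among the compounds named here.

Measured so far:
compound 1 `O=C(Nc1ccccc1F)N1c2ccnn2CC1c1ccccc1`: > 1000 nM
compound 2 `CCOC(=O)c1cnn2c1N(C(=O)Nc1ccccc1)C(c1ccccc1)C2`: > 1000 nM

In a functional assay on cells (Neutrophil, Homo sapiens) for inhibition, with a stated time of 10 min (on this read-out lower numbers stand for stronger inhibition and higher numbers for weaker inhibition), compound 1 gives > 1000 nM, which is a limit and not a number. Compound 2 gives > 1000 nM, which is also a limit. Both values therefore sit at one limit: the limit of > 1000 nM in this assay, at which 2 of the 2 values shown sit. Compound 3 `CCOC(=O)c1cnn2c1N(C(=O)Nc1ccccc1F)C(c1ccccc1)C2` differs from compound 2 by fluoro in place of hydrogen on an aromatic carbon, with fluoro in place of hydrogen on an aromatic carbon, ortho to a large group. For the measured compounds named here, no measured step shows the effect of this change in this assay, so no shift beyond the scatter, in either direction, is expected. The expected step is a step that the limit leaves unreadable from compound 2 to compound 3. The estimate for compound 3 is 1500 nM, with an expected range from 300 nM to 5000 nM.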

Compound 3, half-maximal inhibitory concentration: 7.5 nM
Compound 3: middle estimate off by 200-fold (2.30 log units), on the high side; measured number outside the range, below it.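

In this assay, compound 3 shows that both groups matter together: fluoro in place of hydrogen on the phenyl gives an at least 130-fold lower number from compound 2 to compound 3 (2.12 log units; beyond the scatter), and adding ethoxycarbonyl gives an at least 130-fold lower number from compound 1 to compound 3 (2.12 log units; beyond the scatter). With only one of the two groups, compound 1 and compound 2 each stand at a limit and not at a number: the limit of > 1000 nM in this assay, at which 2 of the 3 values shown sit.

From the compounds shown here alone, it remains open whether chloro or methoxy could stand in for fluoro at this place. Equally open, going by these compounds, is whether a carboxylic acid or a primary amide could replace the ethoxycarbonyl and keep the number of compound 3.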